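The source may report more compounds than this note shows. Statements on the series, on what has been measured and on what is new or still open speak of the compounds shown alone.

Measured so far:
compound 1, `COc1ccccc1N1CCN(CCCNc2cncnc2C(=O)N(C)C)CC1`, 50.1 nM
compound 2, `CN(C)C(=O)c1cccnc1NCCCN1CCN(c2ccccc2O)CC1`, 63.1 nM

Both were run in a functional assay on aorta for antagonist activity at Alpha-1D adrenergic receptor (Rattus norvegicus); a lower number here means tighter binding, a higher number weaker binding. Compound 2 stands at the highest of the two numbers; its nearest neighbour is compound 1, and the gap between them lies within the scatter, so the two cannot be told apart on these data. Going by the values given here, no pair of measured compounds differs in only one place, so nothing measured here shows how large a change at a single position moves the number in this assay.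

Compound 3, `CN(C)C(=O)c1cccnc1NCCCN1CCN(c2ccccc2Cc2ccccc2)CC1`, is not yet measured. It differs from compound 2 in one place: benzyl in place of hydroxy on an aromatic carbon. The hydroxy, with its one hydrogen-bond donor and one hydrogen-bond acceptor, leaves; the benzyl, with one six-membered aromatic ring of carbon only, enters on an aromatic carbon ortho to a large group.

Among the compounds with values here, with no measured step of this kind to lean on, the expectation rests on compound 2 at 63.1 nM and on the size of the change. A shift toward a higher number, beyond the scatter, is expected in this assay, as a step of a 2.4-fold higher number from compound 2 to compound 3 (0.38 log units; beyond the scatter). Compound 3 is therefore estimated at 150 nM, with a range from 40 nM to 600 nM.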

Compound 3, dissociation constant: 79.4 nM
For compound 3 the middle estimate is 1.9-fold (0.28 log units) above the measured one; the measured number falls inside the stated range.
By their numbers in this assay, from the lowest: compounds 1, 2 and 3 (each within the scatter of the next).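

In this assay, going by these compounds alone, the first single-place step, benzyl in place of hydroxy on an aromatic carbon ortho to a large group gives a 1.3-fold higher number from compound 2 to compound 3 (0.10 log units; within the scatter), so the two compounds cannot be told apart on these data. At this position, then, the single oxygen of the hydroxy, with its hydrogen-bond donor and acceptor, can give way to the seven carbons and aromatic ring of the benzyl, which has neither, without a shift beyond the scatter. No supporting measurement is available to explain why the number holds across so large a change in the group.

The compounds shown leave open whether an amine, a carboxylic acid or a longer chain ending in a phenyl ring on the same aromatic carbon would also stay within the scatter of compound 2 at 63.1 nM. Compound 1 differs from compound 2 and compound 3 in more than one place, so the effect of its core and of its aromatic substituent cannot be separated.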